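The source may report more compounds than this note shows. Statements on the series, on what has been measured and on what is new or still open speak of the compounds shown alone.

Measured in an ADME assay (liver) for metabolic stability, with Liver microsome (Rattus norvegicus) as the target, using microsomes; a lower number here means slower removal, a higher number faster removal of the compound:
- Compound 1 `Fc1cccc(CNc2nnc(-c3c[nH]c4ncccc34)o2)c1`: 71 mL.min-1.g-1
- Compound 2 `c1ccc(CNc2nnc(-c3c[nH]c4ncccc34)o2)nc1`: 14 mL.min-1.g-1

Compound 2 stands lowest of the two numbers in this assay. Compound 3 `c1cnc2[nH]cc(-c3nnc(NCc4ccncc4)o3)c2c1` differs from it by pyridin-4-yl in place of pyridin-2-yl on a saturated chain carbon bound to a nitrogen on an aromatic ring, with pyridin-4-yl in place of pyridin-2-yl. Among the compounds with values here, the only measured step that bears on this is a 5.1-fold lower number from compound 1 to compound 2 (0.71 log units; beyond the scatter), and it replaced 3-fluorophenyl, not one pyridinyl with another. Within the data shown here, no measured pair shows the present swap, so a step beyond the scatter is not expected, and the estimated change is a 1.4-fold higher number from compound 2 to compound 3 (0.15 log units; within the scatter). For compound 3 the estimated value is 20 mL.min-1.g-1, with an expected range of 9 mL.min-1.g-1 to 45 mL.min-1.g-1.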

Compound 3, intrinsic clearance in microsomes: 37 mL.min-1.g-1
Beside the measured number, compound 3's estimate is 1.9-fold (0.27 log units) below it; measured number inside the range.
By their numbers in this assay, from the lowest: compound 2; then compounds 3 and 1 (each within the scatter of the next).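

In this assay, the nitrogen's place in the ring matters at this position on a saturated chain carbon bound to a nitrogen on an aromatic ring: with the same atoms joined differently, pyridin-4-yl in place of pyridin-2-yl gives a step beyond the scatter (a 2.6-fold higher number from compound 2 to compound 3 (0.42 log units; beyond the scatter)). So a pyridine ring alone does not set the number, since pyridin-4-yl stays within the scatter of 3-fluorophenyl (a 1.9-fold lower number from compound 1 to compound 3 (0.28 log units; within the scatter)). No evidence here explains the difference between the two pyridinyl groups. Open, from the compounds shown here alone, is where pyridin-3-yl would fall, and whether a longer chain carrying pyridin-2-yl would keep the number of compound 2.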